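The compounds below may be only part of what the source reports. "The series", "measured", "known", "first", "only" and "open" are said of these compounds alone.

In a functional assay on HT-29 cells (Homo sapiens) for inhibition, read by sulforhodamine B assay, with a stated time of 72 h (a lower number here means a stronger inhibitor, a higher number a weaker inhibitor), compound 1 `COc1ccc(C2C(O)C(=O)N2c2cc(OC)c(OC)c(OC)c2)cc1` gives 12 nM. Compound 3 `CCOc1ccc(C2C(O)C(=O)N2c2cc(OC)c(OC)c(OC)c2)cc1`, at 15 nM, lies within the scatter of it, while compound 2 `COc1ccc(C2C(O)C(=O)N2c2cc(OC)c(OC)c(OC)c2)cc1O` gives a clearly higher 463 nM. Compound 4 `COc1ccc(C2CC(=O)N2c2cc(OC)c(OC)c(OC)c2)cc1` departs from compound 1 at one place: hydrogen in place of hydroxy on a saturated ring carbon. For the measured compounds named here, no measured step touches that carbon, so the evidence is only indirect. The large 39-fold higher number from compound 1 to compound 2 (1.59 log units; beyond the scatter) comes with a hydroxy added on an aromatic carbon, showing that a hydroxy can matter, whereas a 1.3-fold higher number from compound 1 to compound 3 (0.10 log units; within the scatter) stays within the scatter. A moderate move towards a higher number is therefore expected, with wide uncertainty. The expected step is a 3.3-fold higher number from compound 1 to compound 4 (0.52 log units; beyond the scatter). For compound 4 the estimated value is 40 nM, with an expected range of 12 nM to 150 nM.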

Compound 4, half-maximal inhibitory concentration: 65 nM
Beside the measured number, compound 4's estimate is 1.6-fold (0.21 log units) below it; the range from low to high includes it.
By their numbers in this assay, from the lowest: compounds 1 and 3 (each within the scatter of the next); then compound 4; then compound 2.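

Taking the hydroxy off this saturated ring carbon gives a 5.4-fold higher number from compound 1 to compound 4 (0.73 log units; beyond the scatter) in this assay, so this carbon, which no earlier step touched, does affect the number. The change is modest, and compound 4 keeps a measurable inhibition without the hydroxy. Nothing available explains why the number rises with this change.

As far as these compounds go, what stays open is how other groups on this carbon would compare, such as a methoxy, an amine or a fluorine. The compounds shown also leave open whether the same change would act alike with a different aromatic group on the neighbouring ring atom.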